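The source may report more compounds than this note shows. Statements on the series, on what has been measured and on what is new or still open speak of the compounds shown alone.

Compound 1 `Oc1cccc(C(c2c[nH]c3ccc(Br)cc23)c2c[nH]c3ccc(Br)cc23)c1` is measured in a functional assay on HeLa cells (Homo sapiens) for inhibition, read by MTT assay, with a stated time of 48 h (on this read-out lower numbers stand for stronger inhibition and higher numbers for weaker inhibition), at 3900 nM, the second highest of the three numbers in hand. Compound 3 `Brc1ccc(C(c2c[nH]c3ccc(Br)cc23)c2c[nH]c3ccc(Br)cc23)cc1` gives 1500 nM in this assay, and compound 2 `COc1cccc(C(c2c[nH]c3ccc(Br)cc23)c2c[nH]c3ccc(Br)cc23)c1OC` gives 64500 nM. Compound 4 `CCCCCCCC(c1c[nH]c2ccc(Br)cc12)c1c[nH]c2ccc(Br)cc12` differs from compound 1 in one place: heptyl in place of 3-hydroxyphenyl on a saturated chain carbon bound to two aromatic carbons. Both measured steps start from compound 1 and replace the same group: a 17-fold higher number from compound 1 to compound 2 (1.22 log units; beyond the scatter), whereas a 2.6-fold lower number from compound 1 to compound 3 (0.41 log units; beyond the scatter). Neither step brings in a chain without a ring, so they show only that this position responds to change in either direction, sometimes strongly. The expected step is a 2.1-fold higher number from compound 1 to compound 4 (0.31 log units; beyond the scatter), a loss that stays inside the span those two steps mark out. Compound 4 is estimated at 8000 nM in this assay, within 2000 nM to 40000 nM.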

Compound 4, half-maximal inhibitory concentration: 1300 nM
The estimate for compound 4 lay 6.2-fold (0.79 log units) above the measured number; measured number outside the range, below it.
By their numbers in this assay, from the lowest: compounds 4 and 3 (each within the scatter of the next); then compound 1; then compound 2.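

In this assay heptyl, which has no ring, gives a 3.0-fold lower number from compound 1 to compound 4 (0.48 log units; beyond the scatter) and a 50-fold lower number from compound 2 to compound 4 (1.70 log units; beyond the scatter) and so shows that a ring at this position is not needed for a low number. In place of 4-bromophenyl, heptyl gives a 1.2-fold lower number from compound 3 to compound 4 (0.06 log units; within the scatter) and so cannot be told apart from it here. Nothing at hand explains this result. Going by these compounds, whether a shorter chain or a longer chain would do as well stays open, as does the effect of an amine or a carboxylic acid at the end of the heptyl chain.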